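The source may report more compounds than this note shows. Statements on the series, on what has been measured and on what is new or still open speak of the compounds shown alone.

Compound 3 `CC(=O)c1ccc(-c2cn3ccnc3c(-c3ccc4ncn(C5CCCCC5)c4c3)n2)cc1` gives 18.8% in a functional assay on HCT-15 cells (Homo sapiens) for inhibition, read by sulforhodamine B assay, with a stated time of 48 h, tested at 10 uM (on this read-out lower numbers stand for less inhibition and higher numbers for more inhibition at the one concentration tested (going by the name of the read-out)), the second highest of three numbers: compound 1 `O=Cc1ccc(-c2cn3ccnc3c(-c3ccc4ncn(C5CCCCC5)c4c3)n2)cc1` gives 49.1%, and compound 2 `c1ccc2c(-c3cn4ccnc4c(-c4ccc5ncn(C6CCCCC6)c5c4)n3)cccc2c1` gives 4.46%. Compound 4 `Clc1ccc(-c2cn3ccnc3c(-c3ccc4ncn(C5CCCCC5)c4c3)n2)cc1` has not yet been measured; it differs from compound 3 by chloro in place of acetyl on an aromatic carbon. For the measured compounds named here, no measured step swaps acetyl for chloro, but two steps show how strongly the group on that phenyl ring sways the read-out: a number 30.3 percentage points lower from compound 1 to compound 3 (beyond the scatter), and a number 14.3 percentage points higher from compound 2 to compound 3 (beyond the scatter). Going by the values given here, the change leaves one hydrogen-bond acceptor behind, and the lowest number so far belongs to compound 2. A drop beyond the scatter is therefore expected, a number 8.8 percentage points lower from compound 3 to compound 4 (within the scatter). Compound 4 is estimated at 10%, within 0% to 30%.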

Compound 4, a percentage reported as inhibition, at one concentration (the size of the read-out at that concentration, not a potency): 15.5%
Compound 4: middle estimate off by 5.5 percentage points, on the low side; measured number inside the range.
By their numbers in this assay, from the lowest: compound 2; then compounds 4 and 3 (each within the scatter of the next); then compound 1.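

In this assay, chloro and acetyl on this ring read alike (a number 3.3 percentage points lower from compound 3 to compound 4 (within the scatter)), so here the hydrogen-bond acceptor that leaves with acetyl makes no difference beyond the scatter. Formyl stands well apart from chloro (a number 33.6 percentage points lower from compound 1 to compound 4 (beyond the scatter)), while 4-chlorophenyl still reads higher than naphthalen-1-yl (a number 11 percentage points higher from compound 2 to compound 4 (beyond the scatter)). Nothing available explains these differences. The compounds shown leave open how an amine or a carboxylic acid would read at this position. They also leave open whether anything else on this ring would match formyl.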